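The source may report more compounds than this note shows. Statements on the series, on what has been measured and on what is new or still open speak of the compounds shown alone.

Measured so far:
compound 1 `CCN(C/C=C/C#CC(C)(C)C)Cc1cccc(OCCN(C)S(=O)(=O)c2ccsc2)c1` gives 250 nM in a functional assay on HepG2 cells for inhibition of squalene monooxygenase (Homo sapiens); a higher number here means a weaker inhibitor, a lower number a stronger inhibitor
compound 2 `CCN(C/C=C/C#CC(C)(C)C)Cc1cccc(OCCN(C)S(=O)(=O)c2ccc(-c3ccsc3)s2)c1` gives 210 nM in this assay

Compound 1 stands with the highest of the two numbers, and its nearest neighbour is compound 2, reached by a 1.2-fold lower number from compound 1 to compound 2 (0.08 log units; within the scatter), where 5-(thiophen-3-yl)thiophen-2-yl stands in place of thiophen-3-yl on a sulfonyl sulfur; that step lies within the scatter.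

Compound 3 `CCN(C/C=C/C#CC(C)(C)C)Cc1cccc(OCCCS(=O)(=O)c2cccs2)c1` has not yet been measured. Its difference from compound 1 is this: a group of 9 heavy atoms (5 carbon, 2 oxygen, 2 sulfur; one five-membered aromatic ring with 1 hetero atom) in place of a group of 10 heavy atoms (5 carbon, 1 nitrogen, 2 oxygen, 2 sulfur; one five-membered aromatic ring with 1 hetero atom), on a saturated chain carbon, two bonds along the chain from an oxygen on an aromatic ring. Going by the values given here, the single measured step, from compound 1 to compound 2, changes only the ring on the sulfonyl sulfur and leaves the chain itself untouched, whereas the change to compound 3 rewrites the chain segment that carries the sulfonyl group. Among the compounds with values here, no measured step therefore bears directly on it, and the one step that exists is itself within the scatter. The expected step is no change at the digits printed from compound 1 to compound 3 (within the scatter), in no particular direction, with a wide margin to allow for the untested chain change. Compound 3 is accordingly estimated at 250 nM in this assay. The estimate for compound 3 runs from 80 nM to 800 nM.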

Compound 3, half-maximal inhibitory concentration: 290 nM
For compound 3 the middle estimate is 1.2-fold (0.06 log units) below the measured one, within the range that was stated.
By their numbers in this assay, from the lowest: compounds 2, 1 and 3 (each within the scatter of the next).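

In this assay, putting a group of 9 heavy atoms (5 carbon, 2 oxygen, 2 sulfur) in place of a group of 10 heavy atoms (5 carbon, 1 nitrogen, 2 oxygen, 2 sulfur), on a saturated chain carbon, two bonds along the chain from an oxygen on an aromatic ring, gives a step of a 1.2-fold higher number from compound 1 to compound 3 (0.06 log units; within the scatter). Going by these compounds alone, the earlier pair differed only in the ring on the sulfonyl sulfur, so this is the first view of a change in the chain itself, and it shows that, for this pair, a compound without the nitrogen of that group still reads within the scatter of compound 1. Nothing measured here accounts for this result.

The whole group differs in one replacement, so the compounds shown do not separate what the loss of the nitrogen contributes from what any other difference within the group contributes. Also open, on these data alone, is how a longer chain, a carboxylic acid in place of the sulfonyl group, or the 5-(thiophen-3-yl)thiophen-2-yl group on this new chain would read in this assay.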